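The compounds below may be only part of what the source reports. "The series", "measured", "known", "first", "only" and "open" are said of these compounds alone.

Three compounds have been measured so far:

Compound 1, `Cc1nc(COc2ccc(/C=C3\SC(=O)NC3=O)cc2)cs1`: in a functional assay on the whole organism (plasma, strain Wistar) with Rattus norvegicus as the target, with a stated time of 15 days, at a dose of 100 mg/kg by the oral route (a higher number here means a stronger effect of the compound at the dose given, a lower number a weaker effect), compound 1 gives 22.9%.
Compound 2, `O=C1NC(=O)/C(=C/c2ccc(OCc3csc(-c4ccccc4)n3)cc2)S1`: in this assay compound 2 gives 29.7%.
Compound 3, `Cc1ccc(-c2nnc(SCCOc3ccc(/C=C4\SC(=O)NC4=O)cc3)[nH]2)cc1`: in this assay compound 3 gives 29.7%.

Compound 3 and compound 2 give the same number at the digits shown, and the gap from compound 1 to compound 3 lies within the scatter of repeated measurements, so the three compounds cannot be told apart on these numbers. For the measured compounds named here, the only step between two measured compounds that differ in one place is a number 6.8 percentage points higher from compound 1 to compound 2 (within the scatter), a change of phenyl in place of methyl on an aromatic carbon that stays within the scatter.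

Compound 4, `O=C1NC(=O)/C(=C/c2ccc(OCCSc3nnc(-c4ccc(Cl)cc4)[nH]3)cc2)S1`, has not yet been measured. It differs from compound 3 by chloro in place of methyl on an aromatic carbon; the 4-methylphenyl of compound 3 becomes 4-chlorophenyl. Going by the values given here, no measured step concerns chloro in place of methyl, so nothing in the data speaks for a shift in either direction. Among the compounds with values here, the one step known, from phenyl in place of methyl, was itself within the scatter. A step of about a number 0.7 percentage points lower from compound 3 to compound 4 (within the scatter) is therefore expected, that is, none beyond the scatter. For compound 4 the expected value in this assay is 29%, with a range from 15% to 44%.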

Compound 4, a percentage reported as activity, at one dose (the size of the read-out at that dose, not a potency): 28.9%
For compound 4 the middle estimate is 0.1 percentage points above the measured one; measured number inside the range.
By their numbers in this assay, from the lowest: compounds 1, 4, 2 and 3 (each within the scatter of the next).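

In this assay, putting chloro in place of methyl, on an aromatic carbon of a six-membered aromatic ring of carbon only and para to a large group, gives a number 0.8 percentage points lower from compound 3 to compound 4 (within the scatter), so at this dose the 4-methylphenyl and 4-chlorophenyl compounds cannot be told apart. For the compounds shown here, this is the first reading at this position, since the only earlier step, a number 6.8 percentage points higher from compound 1 to compound 2 (within the scatter), concerned a different place in a different pair, and it shows that here, too, a single exchange of one heavy atom for another leaves the read-out within the scatter. No measurement available here accounts for the two groups reading alike.

All the steps among these four compounds stay within the scatter, so it remains open whether anything at this position can move the number at all, for instance an amine, a carboxylic acid or a methoxy group in place of the chloro. Also open, from the compounds shown here alone, is whether a longer chain between the sulfur and the shared core would give a number that stands clearly apart from those of compound 3 and compound 4.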